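Thiourea variants on a shared core: next ring substituent

The source may hold more compounds than are shown below. What is called first, only, known or untested is meant among the compounds shown, and "the series" means these compounds.

The set shares one core, first seen in compound 1 `NC(=O)c1c(NC(=O)c2ccccc2Cl)sc2c1CCN(Cc1ccccc1)C2`. In a functional assay on HL-60 cells (Homo sapiens) for antiproliferative activity, with a stated time of 24 h (a higher number here means a weaker inhibitor, a lower number a stronger inhibitor), compound 1 gives 12000 nM. Compound 2 `Cc1ccccc1CN1CCc2c(sc(NC(=O)c3ccccc3Cl)c2C(N)=O)C1` in this assay reaches only > 50000 nM, which is a limit of the assay and not a number. The step between them is an at least 4.1-fold higher number from compound 1 to compound 2 (0.61 log units; beyond the scatter); what is known of it is only (the limit of > 50000 nM in this assay, at which 1 of the 3 values shown sits). Compound 3 `NC(=O)c1c(NC(=O)c2ccccc2Cl)sc2c1CCN(C(=S)Nc1ccccc1)C2` in this assay gives 5940 nM, the lowest of the two numbers shown, with compound 1 nearest. The moves toward it read a 2.0-fold lower number from compound 1 to compound 3 (0.31 log units; beyond the scatter) and an at least 8.4-fold lower number from compound 2 to compound 3 (0.92 log units; beyond the scatter).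

Compound 4 `NC(=O)c1c(NC(=O)c2ccccc2Cl)sc2c1CCN(C(=S)Nc1ccccc1-c1ccccc1)C2` is not yet measured. It differs from compound 3 by phenyl in place of hydrogen on an aromatic carbon. Among the compounds with values here, the one measured step that adds a substituent to an aromatic carbon of a group on the ring amine nitrogen is an at least 4.1-fold higher number from compound 1 to compound 2 (0.61 log units; beyond the scatter), a worsening that ran past the limit. The new ring in compound 4 sits on the thiourea phenyl rather than the benzyl, so the carry-over is uncertain, but the expectation is a weakening of modest size, a 2.5-fold higher number from compound 3 to compound 4 (0.40 log units; beyond the scatter). Compound 4 is therefore expected to give 15000 nM, in a range from 4000 nM to 50000 nM, with a fair chance that only a limit is reported.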

Compound 4, half-maximal inhibitory concentration: 34400 nM
The estimate for compound 4 lay 2.3-fold (0.36 log units) below the measured number, and the stated range covers the measured number.
By their numbers in this assay, from the lowest: compound 3; then compound 1; then compound 4. At a limit, above all of these: compound 2.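

In this assay, within the data shown here, a 5.8-fold higher number from compound 3 to compound 4 (0.76 log units; beyond the scatter) is the first step with a full size for a substituent added to the aromatic ring of the group on the ring amine nitrogen, here phenyl in place of hydrogen, on an aromatic carbon ortho to a large group. The earlier step of this kind, an at least 4.1-fold higher number from compound 1 to compound 2 (0.61 log units; beyond the scatter), is known only as a limit: the limit of > 50000 nM in this assay, at which 1 of the 4 values shown sits. Taken together, these two steps, methyl on the benzyl ring and phenyl on the thiourea phenyl ring, both go with a higher number, and no compound shown goes against this, though the pattern rests on only two pairs with different groups on the ring amine nitrogen.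

With phenyl the only substituent shown on the thiourea phenyl ring, it remains open whether a smaller group at the same place, such as methyl, hydroxyl or an amine, would also raise the number. Also open, as far as these compounds go, is how the same phenyl would read at other places on that ring, or with oxygen in place of the thiourea sulfur.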